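Amide to Urea on the Shared Core

The source may hold more compounds than are shown below. What is called first, only, known or untested is meant among the compounds shown, and "the series" means these compounds.

Measured compounds:
compound 1 `COc1cc(-c2nn(-c3cccc(NC(=O)c4cccc(C(F)(F)F)c4)c3)cc2-c2ccncc2)ccc1Cl` gives 1240 nM
compound 2 `COc1cc(-c2nn(-c3cccc(NC(=O)Nc4ccc(Cl)c(Cl)c4)c3)cc2-c2ccncc2)ccc1Cl` gives 698 nM
compound 3 `COc1cc(-c2nn(-c3cccc(NC(=O)c4ccc(Cl)c(C(F)(F)F)c4)c3)cc2-c2ccncc2)ccc1Cl` gives 1200 nM

All three compounds were tested in a functional assay on MDA-MB-231 cells (Homo sapiens) for inhibition, read by sulforhodamine B assay, with a stated time of 48 h; on this read-out lower numbers stand for stronger inhibition of growth and higher numbers for weaker inhibition of growth. Compound 3 stands second highest of the three numbers. Its nearest neighbour is compound 1, as the step of a 1.0-fold lower number from compound 1 to compound 3 (0.01 log units; within the scatter) is within the scatter; its furthest neighbour is compound 2, where the step of a 1.7-fold higher number from compound 2 to compound 3 (0.24 log units; within the scatter) is also within the scatter.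

Compound 4 `COc1cc(-c2nn(-c3cccc(NC(=O)Nc4ccc(Cl)c(C(F)(F)F)c4)c3)cc2-c2ccncc2)ccc1Cl` has not yet been measured. It differs from compound 3 in one place: (4-chloro-3-(trifluoromethyl)phenyl)amino in place of 4-chloro-3-(trifluoromethyl)phenyl on a carbonyl carbon. The measured step that bears on this is a 1.8-fold lower number from compound 1 to compound 2 (0.25 log units; within the scatter), where the same carbonyl-to-urea exchange occurred together with a change in the aryl group, and the step stayed within the scatter. Compound 2, the only urea measured so far, sits at the low end of the three numbers.

For compound 4, the step of a 1.6-fold lower number from compound 3 to compound 4 (0.20 log units; within the scatter) is therefore expected to be small, if anything in the direction of a lower number, but likely not beyond the scatter. The estimate for compound 4 in this assay is 750 nM, with a range from 350 nM to 1600 nM.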

Compound 4, concentration for 50% growth inhibition: 760 nM
Compound 4: middle estimate off by 1.0-fold (0.01 log units), on the low side, within the range that was stated.
By their numbers in this assay, from the lowest: compounds 2, 4, 3 and 1 (each within the scatter of the next).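

Within the data shown here, with compound 4 the exchange on the carbonyl carbon can be read alone for the first time: with 4-chloro-3-(trifluoromethyl)phenyl unchanged, the step of a 1.6-fold lower number from compound 3 to compound 4 (0.20 log units; within the scatter) in this assay stays within the scatter, so urea and amide are not told apart on this aryl group. Among the ureas, the step of a 1.1-fold higher number from compound 2 to compound 4 (0.04 log units; within the scatter) gives the first reading of trifluoromethyl in place of chloro on an aromatic carbon with nothing else altered, and it too stays within the scatter. The step of a 1.6-fold lower number from compound 1 to compound 4 (0.21 log units; within the scatter) joins the urea exchange with an added chloro on the ring, and even these two changes together stay within the scatter, so all four compounds remain one group on this read-out.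

No other measurement is at hand to explain why these exchanges leave the numbers so close. Still open, from the compounds shown here alone, is whether an amine or a carboxylic acid on that phenyl ring, or a longer chain such as an ethylene link in place of the amino group on the carbonyl carbon, would carry the number beyond the scatter.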